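This account rests on a few compounds, and the source may have more. Where it says the series, first, only, none or still open, it means among the compounds named here.

Of the compounds shown here, three have been measured in a functional assay on RPMI8266 cells (Homo sapiens) for inhibition, read by sulforhodamine B assay, with a stated time of 48 h; a lower number here means a stronger inhibitor of growth, a higher number a weaker inhibitor of growth. Compound 1 `COc1cc(C)cc(-c2c(-c3ccnc(-c4ccc(C(C)=O)cc4)c3)cnn2CC#N)c1` gives 9020 nM. Compound 2 `Cc1cc(O)cc(-c2nn(CC#N)cc2-c2ccnc(-c3ccc(Oc4ccccc4)cc3)c2)c1` gives 6520 nM, and compound 3 `Cc1cc(O)cc(-c2nn(CC#N)cc2-c2ccnc(-c3ccc(N(C)C)cc3)c2)c1` gives 22200 nM. Among these three numbers compound 1 stands second highest: its value and that of compound 2 lie within the scatter of each other, so no order between them can be claimed, while compound 3 sits above both of them by more than the scatter.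

Compound 4 `COc1cc(C)cc(-c2c(-c3ccnc(-c4ccc(N(C)C)cc4)c3)cnn2CC#N)c1` has not yet been measured. It differs from compound 1 in one place: dimethylamino in place of acetyl on an aromatic carbon. For the measured compounds named here, the only measured step that bears on this change is a 3.4-fold higher number from compound 2 to compound 3 (0.53 log units; beyond the scatter), where the same dimethylamino group enters the same position, though there it replaces a phenoxy group rather than an acetyl group, and on a core that carries a hydroxy group where compound 1 carries a methoxy group. That step is modest and points toward a weaker inhibitor of growth. The change from compound 1 to compound 4 is therefore expected to move in the same direction, with the step of a 2.4-fold higher number from compound 1 to compound 4 (0.39 log units; beyond the scatter) as the estimate. On that basis compound 4 is expected to give about 22000 nM in this assay, within a range from 9000 nM to 55000 nM.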

Compound 4, concentration for total growth inhibition: 1960 nM
Compound 4: middle estimate off by 11-fold (1.05 log units), on the high side; the measured number lies below the stated range.
By their numbers in this assay, from the lowest: compound 4; then compounds 2 and 1 (each within the scatter of the next); then compound 3.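

In this assay, dimethylamino in place of acetyl on this aromatic carbon, para to a large group, gives a 4.6-fold lower number from compound 1 to compound 4 (0.66 log units; beyond the scatter), so on the core of compound 1 the change yields a stronger inhibitor of growth. The same group entering the same place went the other way in a 3.4-fold higher number from compound 2 to compound 3 (0.53 log units; beyond the scatter), which shows that dimethylamino has no single effect here: the direction of its step changes with the pair it is read in, and those two pairs differ both in the group that leaves, phenoxy or acetyl, and in the core, which is not the same in compound 1 as in compound 2. Nothing measured here accounts for this reversal.

As far as these compounds go, it stays open whether the reversal follows the group that is replaced or the core, as the two steps differ in both at once. From the compounds shown here alone, it is equally open whether another amine, such as pyrrolidine or a primary amino group, would match dimethylamino at this place on the core of compound 1.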